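Replacing the phosphorus group with carboxymethyl

The source may report more compounds than this note shows. Statements on the series, on what has been measured and on what is new or still open speak of the compounds shown alone.

Compound 1 `CC(C)OCc1nc(Nc2ccc(C(F)(F)F)cc2)c2ccc(-c3ncccc3C(F)(F)F)cc2n1`: 0.04 ug/mL
Compound 2 `O=P(O)(O)OCc1nc(Nc2ccc(C(F)(F)F)cc2)c2ccc(-c3ncccc3C(F)(F)F)cc2n1`: > 138 ug/mL

These values come from a physicochemical assay for solubility, at pH 7.4; a lower number here means a less soluble compound, a higher number a more soluble compound. Compound 2 gives > 138 ug/mL, which is a limit of the assay and not a number. Compound 2 stands at the limit of > 138 ug/mL in this assay, at which 1 of the 2 values shown sits.

Compound 3 `O=C(O)COCc1nc(Nc2ccc(C(F)(F)F)cc2)c2ccc(-c3ncccc3C(F)(F)F)cc2n1` changes one group: a group of 4 heavy atoms (2 carbon, 2 oxygen; no ring) in place of a group of 4 heavy atoms (3 oxygen, 1 phosphorus; no ring), on an oxygen on a saturated carbon. For the measured compounds named here, the only measured step that bears on this is an at least 3400-fold higher number from compound 1 to compound 2 (3.53 log units; beyond the scatter), which brought in the group that now leaves. Only part of that rise is expected to survive the swap, so a fall in this assay is likely. The expected step is an at least 5.5-fold lower number from compound 2 to compound 3 (0.74 log units; beyond the scatter). Compound 3 is estimated at 25 ug/mL, with an expected range of 3 ug/mL to 150 ug/mL.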

Compound 3, solubility: 125 ug/mL
Estimate against measurement, compound 3: 5.0-fold (0.70 log units) below, and the stated range covers the measured number.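

In this assay, carboxymethyl in place of isopropyl gives a 3100-fold higher number from compound 1 to compound 3 (3.49 log units; beyond the scatter), so a large rise at this oxygen does not depend on phosphorus. Compound 2 carries a limit and not a number: the limit of > 138 ug/mL in this assay, at which 1 of the 3 values shown sits. For the compounds shown here, the only reading against it is an at least 1.1-fold lower number from compound 2 to compound 3 (0.04 log units; that floor lies within the scatter), so the true distance between these two compounds stays unknown.

Still open, from the compounds shown here alone, is whether an aminoethyl group or a longer chain such as carboxyethyl on the same oxygen would keep a number of this size. Going by these compounds, whether carboxymethyl does the same on a different core also remains open.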